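This account rests on a few compounds, and the source may have more. Where it says the series, first, only, none or still open, it means among the compounds named here.

Measured compounds:
compound 1 `CC(C)n1nc(-c2ccccc2)c(-c2ccccc2)cc1=O` — 152000 nM
compound 2 `CCCCn1nc(-c2ccccc2)c(-c2ccccc2)cc1=O` — 176000 nM
compound 3 `CCCCCCCOc1cc(-c2ccccc2)c(-c2ccccc2)nn1` — 58000 nM

All three numbers come from an assay on microsomes from liver for inhibition of sterol O-acyltransferase 1 (Rattus norvegicus); a higher number here means a weaker inhibitor, a lower number a stronger inhibitor. Compound 3 stands lowest of the three; compound 1 is nearest and compound 2 furthest, both gaps beyond the scatter, so compound 3 is the strongest inhibitor measured so far. Going by the values given here, compound 1 and compound 2 share a core that is not the core of compound 3, and the only single-point step among the measured compounds, a 1.2-fold higher number from compound 1 to compound 2 (0.06 log units; within the scatter), exchanges an alkyl group on an aromatic nitrogen.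

Compound 4 `CCCCCCC[S+]([O-])c1cc(-c2ccccc2)c(-c2ccccc2)nn1` differs from compound 3 where the heptyloxy group sits: a group of 9 heavy atoms (7 carbon, 1 oxygen, 1 sulfur; no ring) in place of a group of 8 heavy atoms (7 carbon, 1 oxygen; no ring), on an aromatic carbon. Among the compounds with values here, no measured step touches that part of the molecule or an exchange of oxygen for sulfur; the single step available, a 1.2-fold higher number from compound 1 to compound 2 (0.06 log units; within the scatter), lies elsewhere in a different core and stayed within the scatter, so it gives no guide to direction. With nothing pointing to a gain or a loss, the expectation for compound 4 in this assay is a number close to that of compound 3, a 1.0-fold higher number from compound 3 to compound 4 (0.01 log units; within the scatter), with wide uncertainty. Compound 4 is estimated at 60000 nM, expected between 15000 nM and 250000 nM.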

Compound 4, half-maximal inhibitory concentration: 77000 nM
For compound 4 the middle estimate is 1.3-fold (0.11 log units) below the measured one; the measured number falls inside the stated range.
By their numbers in this assay, from the lowest: compounds 3, 4, 1 and 2 (each within the scatter of the next, the first and the last beyond it).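

In this assay the heptyloxy position on the aromatic carbon now has its first step: the group of 9 heavy atoms (7 carbon, 1 oxygen, 1 sulfur; no ring) in its place gives a 1.3-fold higher number from compound 3 to compound 4 (0.12 log units; within the scatter) and so stays within the scatter. This position therefore tolerates this exchange in the core of compound 3, which the earlier step, an alkyl exchange on an aromatic nitrogen in a different core, could not show. No available evidence bears on this result.

Still open, on these data alone, is whether an amine, a carboxylic acid or a butyl chain on this aromatic carbon would move the number beyond the scatter. Also open, as far as these compounds go, is whether a sulfur-linked heptyl group without the oxygen would read the same way as these two groups.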